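The source may report more compounds than this note shows. Statements on the series, on what has been measured and on what is new or still open speak of the compounds shown alone.

Among the compounds with values here, in a functional assay on U-87MG ATCC cells for antiproliferative activity against U-87 MG (Homo sapiens), read by spectrophotometry, with a stated time of 2 days (a lower number here means a stronger inhibitor of growth, a higher number a weaker inhibitor of growth), compound 3 `COc1cc(Nc2ncc(C(F)(F)F)c(N3Cc4cccc(N(C)S(C)(=O)=O)c4C3)n2)c(OC)cc1Cl` is the only member of this small set with a number rather than a limit: compound 3 gives 6200 nM. Compound 1 `CN(c1cccc2c1CN(c1nc(Nc3ccc(C(F)(F)F)cc3)ncc1C(F)(F)F)C2)S(C)(=O)=O` sits at the limit of this assay, > 30000 nM. Compound 2 `CN(c1cccc2c1CN(c1nc(Nc3cccc(C(F)(F)F)c3)ncc1C(F)(F)F)C2)S(C)(=O)=O` likewise sits at the limit, > 30000 nM. Between the two the change is a step that the two limits leave unreadable from compound 1 to compound 2. The two steps that reach compound 3 both run the same way: an at least 4.8-fold lower number from compound 1 to compound 3 (0.68 log units; beyond the scatter) and an at least 4.8-fold lower number from compound 2 to compound 3 (0.68 log units; beyond the scatter); both rest on (the limit of > 30000 nM in this assay, at which 2 of the 3 values shown sit).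

Compound 4 `CN(c1cccc2c1CN(c1nc(Nc3cc(Cl)cc(C(F)(F)F)c3)ncc1C(F)(F)F)C2)S(C)(=O)=O` differs from compound 3 in 3-chloro-5-(trifluoromethyl)phenyl in place of 4-chloro-2,5-dimethoxyphenyl on a nitrogen on an aromatic ring. This undoes the kind of change that brought the number down: compound 4 carries a trifluoromethylphenyl as compound 1 and compound 2 do, with a chlorine added. The steps from compound 1 and compound 2 to compound 3 therefore bear directly on it, and in this assay the number for compound 4 is expected to climb back toward the limit. Compound 4 is expected to show a step of a 4.8-fold higher number from compound 3 to compound 4 (0.68 log units; beyond the scatter). Compound 4 is estimated at 30000 nM, with a range from 8000 nM to 80000 nM, and a limit rather than a number would not be surprising.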

Compound 4, concentration for 50% growth inhibition: 5500 nM
Compound 4: middle estimate off by 5.5-fold (0.74 log units), on the high side; measured number outside the range, below it.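

In this assay, the methoxy groups of compound 3 prove not to be required for a measurable number on this nitrogen: 3-chloro-5-(trifluoromethyl)phenyl, which keeps a trifluoromethyl group and carries no oxygen, also gives one. With chloro in place of hydrogen on an aromatic carbon there is an at least 5.4-fold lower number from compound 2 to compound 4 (0.73 log units; beyond the scatter), and the change from 4-(trifluoromethyl)phenyl gives an at least 5.4-fold lower number from compound 1 to compound 4 (0.73 log units; beyond the scatter), so a trifluoromethylphenyl on this nitrogen does not by itself leave a compound at the limit, and both steps are minimum sizes that rest on this: the limit of > 30000 nM in this assay, at which 2 of the 4 values shown sit. The two different aryl groups of the other pair give a 1.1-fold lower number from compound 3 to compound 4 (0.05 log units; within the scatter), so the assay does not separate them, even though one has two methoxy groups and the other a trifluoromethyl group.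

The compounds shown leave open whether a bromine or a nitrile in place of the chloro would serve as well, and whether the chloro would have the same effect on a phenyl ring without a trifluoromethyl group. They also leave open whether an amine or a carboxylic acid on this phenyl ring would move the number away from the level shared by compound 3 and compound 4.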